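Swapping a Hydroxy for a Fluoro on a Shared Core

The compounds below may be only part of what the source reports. "The series", "measured", "known", "first", "only" and "open" are said of these compounds alone.

Measured compounds:
- Compound 1, `O=C1CSC(c2cccc(O)c2)N1CCN1CCCCC1`: 100%
- Compound 2, `O=C1CSC(c2ccc([N+](=O)[O-])cc2)N1CCN1CCCCC1`: 66%
- Compound 3, `O=C1CSC(c2ccccc2[N+](=O)[O-])N1CCN1CCCCC1`: 100%

Of the compounds shown here, three built on the same core have been tested in an ADME assay on Vero cells (Chlorocebus sabaeus) for cytotoxicity, read by neutral red uptake, tested at 394 ug/mL; on this read-out lower numbers stand for a stronger effect and higher numbers for a weaker effect at the one concentration tested. Compound 1 gives 100%, and compound 3 gives 100%; these two numbers match at the digits shown, and together they are the highest of the three. Compound 2 gives 66%, a number clearly lower than that of compound 1, beyond the usual scatter of this kind of measurement. For the measured compounds named here, no single-point step between any two of the measured compounds has been worked out, so only the bare values can be compared.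

The next compound to be looked at is compound 4, `O=C1CSC(c2cccc(F)c2)N1CCN1CCCCC1`. It differs from compound 1 in one place:

fluoro in place of hydroxy on an aromatic carbon

Going by the values given here, nothing among the measured compounds tells how this particular exchange plays out in this assay. Compound 1 sits at the top of the scale, so any move that is detectable can only go downward, toward a stronger effect. A modest downward step, or none beyond the scatter, is the expectation here. Compound 4 is estimated at 92%, with a plausible range from 70% to 100%. The expected move from compound 1 to compound 4 is a number 8 percentage points lower from compound 1 to compound 4 (within the scatter).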

Compound 4, a percentage reported as activity, at one concentration (the size of the read-out at that concentration, not a potency): 60%
The estimate for compound 4 lay 32 percentage points above the measured number, outside the stated range (below it).
By their numbers in this assay, from the lowest: compounds 4 and 2 (each within the scatter of the next); then compounds 1 and 3 (each within the scatter of the next).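

In this assay, the change from 3-hydroxyphenyl to 3-fluorophenyl gives a number 40 percentage points lower from compound 1 to compound 4 (beyond the scatter). For the compounds shown here, until this result, no single exchange on the shared core could be read, so this is the first direct sign that the group on this aromatic carbon matters for the read-out, even though only one heavy atom is exchanged. The count of hydrogen-bond donors and acceptors also changes, since hydroxy has one of each and fluoro has neither, but no measurement at hand links this or anything else to the size of the step.

Going by these compounds alone, with only this one exchange, the effect of losing hydroxy cannot be separated from the effect of gaining fluoro, and a plain hydrogen, a chloro, a methoxy or an amine on the same aromatic carbon would help to tell the two apart. As far as these compounds go, it also remains open whether fluoro in place of hydroxy would give a step of similar size on another carbon of the aromatic ring, or on a compound with a different group elsewhere on the shared core.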